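A Branched Amine Gives Way to a Straight One

This account rests on a few compounds, and the source may have more. Where it says the series, first, only, none or still open, it means among the compounds named here.

compound 1 `C=CCNc1nc(N)c(C(=O)N=C(N)N)nc1Cl` — 16%
compound 2 `CC(C)(C)Nc1nc(N)c(C(=O)N=C(N)N)nc1Cl` — "not determined" (no result reported)

In an assay for inhibition of acid-sensing ion channel 3 (Homo sapiens), read by patch clamp, tested at 1 uM (a lower number here means less inhibition, a higher number more inhibition at the concentration tested (going by the name of the read-out)), compound 1 gives 16%. In this assay compound 2 is reported as "not determined" (no result reported), so where it stands cannot be read from the figures at hand. Compound 3 `CCCN(C)c1nc(N)c(C(=O)N=C(N)N)nc1Cl` differs from compound 2 in one place: methyl(propyl)amino in place of (tert-butyl)amino on an aromatic carbon. For the measured compounds named here, with no step between measured compounds to lean on, the expected change in this assay is of no clear direction and is not expected to exceed the scatter. Going by the values given here, the sole anchor is compound 1 with 16%, which points to low inhibition. Compound 3 is therefore expected to give 15%, with a range of 0% to 35%.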

Compound 3, a percentage reported as inhibition, at one concentration (the size of the read-out at that concentration, not a potency): 32%
The estimate for compound 3 lay 17 percentage points below the measured number, and the stated range covers the measured number.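

In this assay, for the compounds shown here, replacing allylamino with methyl(propyl)amino on an aromatic carbon of the shared core gives a number 16 percentage points higher from compound 1 to compound 3 (beyond the scatter), the only step that can be read at this position. The change from (tert-butyl)amino to methyl(propyl)amino cannot be read, as compound 2 has no number. No measurement at hand accounts for the step.

From the compounds shown here alone, whether the methyl on the nitrogen or the propyl chain goes with the higher number stays open. So does how a pyrrolidine ring or a longer chain such as butyl would read at this position.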